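The compounds below may be only part of what the source reports. "The series", "measured", "known", "first", "only" and "open" are said of these compounds alone.

Notes on the anilide series

Compound 2 `O=C(CN1CCN(c2nnc(Cc3ccncc3)c3ccccc23)CC1)Nc1cccc(F)c1` stands lowest of the two numbers recorded in a functional assay on MDA-MB-231 cells (Homo sapiens) for cytotoxicity, read by MTT assay, with a stated time of 72 h (a higher number here means a weaker inhibitor, a lower number a stronger inhibitor), at 4.4 nM. Going by the values given here, the only other measured member, compound 1 `Cc1cccc(Cl)c1NC(=O)CN1CCN(c2nnc(Cc3ccncc3)c3ccccc23)CC1`, gives 2670 nM in this assay, so the gap is a 610-fold lower number from compound 1 to compound 2 (2.78 log units; beyond the scatter); that step exchanges the whole aryl group on the amide-type nitrogen and shows how much this assay responds to that part of the molecule.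

Compound 3 `O=C(CN1CCN(c2nnc(Cc3ccncc3)c3ccccc23)CC1)Nc1cccc(Br)c1` differs from compound 2 by a single change: bromo in place of fluoro on an aromatic carbon. Among the compounds with values here, no measured pair in the set isolates such a halogen exchange on the amide aryl group; the step from compound 1 to compound 2 bears on the region but not on the size of this particular change, so it sets no expectation of direction. The change keeps the ring, the single substituent and its position and adds neither donor nor acceptor. The step from compound 2 to compound 3 is therefore expected to be small, a 1.6-fold higher number from compound 2 to compound 3 (0.20 log units; within the scatter), most likely within the scatter, with a modest loss of potency somewhat more likely than a gain. Compound 3 is estimated at 7 nM, in the range 2 nM to 30 nM.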

Compound 3, half-maximal inhibitory concentration: 1.7 nM
The estimate for compound 3 lay 4.1-fold (0.61 log units) above the measured number, and the stated range ends above it.
By their numbers in this assay, from the lowest: compound 3; then compound 2; then compound 1.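

At this position, on an aromatic carbon meta to a large group, the identity of the halogen registers in this assay: bromo in place of fluoro gives a 2.6-fold lower number from compound 2 to compound 3 (0.41 log units; beyond the scatter), a modest step but one beyond the scatter, although no ring, hydrogen-bond donor or hydrogen-bond acceptor enters or leaves. The exchange of the whole aryl group on the amide-type nitrogen now also reads a 1600-fold lower number from compound 1 to compound 3 (3.20 log units; beyond the scatter), so the large separation from the 2-chloro-6-methylphenyl group seen with 3-fluorophenyl also holds with 3-bromophenyl. No measurement of any property of these groups is at hand to account for the step between the two halogens.

The compounds shown leave open whether this position responds to halogens alone or whether a methyl, a methoxy, a nitrile, an amine or a carboxylic acid in the same place would hold the number of compound 3. They also leave open whether bromo keeps its effect elsewhere on the ring, and whether the chloro or the methyl of compound 1 accounts for more of its distance from the other two compounds.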